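Cytotoxicity Limits for Three Analogues and an Untested Fourth

The source may hold more compounds than are shown below. What is called first, only, known or untested is meant among the compounds shown, and "the series" means these compounds.

Measured compounds:
compound 1, `Cc1nc(-c2cccnc2)sc1-c1nnc(-c2ccc([N+](=O)[O-])cc2)o1`: > 100 ug/mL
compound 2, `Cc1ccc(-c2nnc(-c3sc(-c4cccnc4)nc3C)o2)cc1`: > 100 ug/mL
compound 3, `Cc1ccccc1-c1nnc(-c2sc(-c3cccnc3)nc2C)o1`: > 100 ug/mL

Three compounds sharing one core were tested in an ADME assay on THP-1 cells (Homo sapiens) for cytotoxicity, read by MTT assay; on this read-out higher numbers stand for lower toxicity in this test and lower numbers for higher toxicity in this test. In this assay compound 1 gives > 100 ug/mL, which is a limit of the assay and not a number. Compound 2 likewise reaches only a limit, > 100 ug/mL. Compound 3 also stands at a limit, > 100 ug/mL.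

Compound 1 differs from compound 2 by nitro in place of methyl on an aromatic carbon; the step that the two limits leave unreadable from compound 2 to compound 1 cannot be sized because both values are limits. The cores of compound 2 and compound 3 differ by 2-methylphenyl in place of 4-methylphenyl on an aromatic carbon, and the step that the two limits leave unreadable from compound 2 to compound 3 is likewise unreadable. All three values sit together at the limit of > 100 ug/mL in this assay, at which 3 of the 3 values shown sit.

Compound 4, `Cc1nc(-c2cccnc2)sc1-c1nnc(-c2ccccc2[N+](=O)[O-])o1`, has not been measured. It differs from compound 3 by nitro in place of methyl on an aromatic carbon. This is the same kind of change as that from compound 2 to compound 1, but not the same: in compound 1 the nitro sits para to a large group, in compound 4 ortho to a large group.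

For compound 4 the expected step is a number no higher from compound 3 to compound 4 (the limit leaves the size open), an estimate resting on compound 3 sitting at the limit > 100 ug/mL and on the three values together at the limit of > 100 ug/mL in this assay, at which 3 of the 3 values shown sit. Compound 4 is therefore expected to give about 100 ug/mL, with a likely span from 50 ug/mL to 200 ug/mL.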

Compound 4, half-maximal cytotoxic concentration: > 100 ug/mL
Compound 4 ended at the assay's limit; the forecaster's own chance of this, stated with the estimate: 80%; the middle value sits exactly at the limit.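

In this assay, compound 3 and compound 4 both reach only a limit of the assay, so no step can be read between them, and the same holds for every other pair shown. All four compounds now stand together: the limit of > 100 ug/mL in this assay, at which 4 of the 4 values shown sit. The compounds shown leave open where any of them would give an actual value in this assay, and whether nitro in place of methyl changes that value at all.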